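Replacing 2-iodophenyl with 2,5-dimethoxyphenyl near the assay limit

The source may report more compounds than this note shows. Statements on the series, on what has been measured and on what is new or still open speak of the compounds shown alone.

Results in an ADME assay on NHDF cells (Homo sapiens) for antiproliferative activity, with a stated time of 72 h; a higher number here means a weaker inhibitor, a lower number a stronger inhibitor:
- Compound 1 `CC(=O)Oc1ccccc1/C=C/c1nc2ccccc2c(=O)[nH]1`: > 25000 nM, a limit
- Compound 2 `CC(=O)Oc1ccccc1/C=C/c1nc(Nc2ccccc2I)c2ccccc2n1`: 23200 nM
- Compound 3 `CC(=O)Oc1cccc(/C=C/c2nc3ccccc3c(=O)[nH]2)c1`: > 25000 nM, a limit

Within the data shown here, compound 2 gives 23200 nM, the only actual number in this set. The other two results are limits of the assay, not numbers (the limit of > 25000 nM in this assay, at which 2 of the 3 values shown sit).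

Compound 4 `COc1ccc(OC)c(Nc2nc(/C=C/c3ccccc3OC(C)=O)nc3ccccc23)c1` has not yet been measured. It carries 2,5-dimethoxyphenyl in place of 2-iodophenyl on a nitrogen on an aromatic ring. Among the measured compounds shown here, no measured pair shows what such a swap does, so only a step within the usual scatter is expected in this assay, with no direction favoured. The expected change is a 1.2-fold lower number from compound 2 to compound 4 (0.06 log units; within the scatter). For the measured compounds named here, the sole numerical anchor is compound 2 at 23200 nM. Compound 4 is estimated at 20000 nM, with an expected range from 8000 nM to 35000 nM.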

Compound 4, half-maximal inhibitory concentration: > 25000 nM
Compound 4 was reported as a limit; the forecaster's own chance of this, stated with the estimate: 45%; middle value at least 1.2-fold (0.09 log units) from the limit.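

In this assay, among these compounds, changing the group on the nitrogen from 2-iodophenyl to 2,5-dimethoxyphenyl gives an at least 1.0-fold higher number from compound 2 to compound 4 (0.03 log units; that floor lies within the scatter) as the only readable step, a floor and not a measured size. The result for compound 4 is a limit, so this first pair at this position shows no stronger inhibition from the swap, and the set gathers at one ceiling: the limit of > 25000 nM in this assay, at which 3 of the 4 values shown sit.

As far as these compounds go, how far past that limit compound 4 lies stays unknown. From the compounds shown here alone, whether a carboxylic acid or an amine in place of these aryl groups on the same nitrogen would give a clearly lower number also stays open.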